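Amino for nitro on a dichlorobenzimidazole aryl series

The source may report more compounds than this note shows. Statements on the series, on what has been measured and on what is new or still open speak of the compounds shown alone.

Of the compounds shown here, three sharing a dichlorinated benzimidazole core have been measured. Compound 3 `O=[N+]([O-])c1ccc(-c2nc3cc(Cl)c(Cl)cc3[nH]2)cc1` carries a nitro group on its pendant ring; in an ADME assay on MDBK cells (Bos taurus) for cytotoxicity, read by MTT assay, with a stated time of 96 h (on this read-out higher numbers stand for lower toxicity in this test and lower numbers for higher toxicity in this test), compound 3 gives 56000 nM. Compound 1 `Nc1ccc(-c2nc3cc(Cl)c(Cl)cc3[nH]2)cc1` differs by amino in place of nitro on an aromatic carbon, and in this assay compound 1 gives 7500 nM. That change produced a 7.5-fold lower number from compound 3 to compound 1 (0.87 log units; beyond the scatter). Compound 2 `COc1ccc(-c2nc3cc(Cl)c(Cl)cc3[nH]2)c([N+](=O)[O-])c1` also carries a nitro group together with a methoxy group, and in this assay compound 2 gives 28000 nM; the difference between the cores of compound 2 and compound 3 is not broken down here, and their two values lie within the scatter of each other.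

Compound 4 `COc1ccc(-c2nc3cc(Cl)c(Cl)cc3[nH]2)c(N)c1` has not yet been measured. It differs from compound 2 by amino in place of nitro on an aromatic carbon. This is the same kind of change as that from compound 3 to compound 1, but the surroundings differ: in the earlier pair the site is para to a large group, whereas here it is ortho to a large group and meta to a methoxy group. Given that the earlier step, a 7.5-fold lower number from compound 3 to compound 1 (0.87 log units; beyond the scatter), lowered the number, a step of similar direction is expected, a 6.2-fold lower number from compound 2 to compound 4 (0.79 log units; beyond the scatter), with a wider margin because of the changed surroundings. Compound 4 is estimated at 4500 nM, between 1500 nM and 14000 nM.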

Compound 4, half-maximal cytotoxic concentration: 6500 nM
Compound 4: middle estimate off by 1.4-fold (0.16 log units), on the low side; the measured number falls inside the stated range.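

In this assay, amino in place of nitro on an aromatic carbon again lowered the number, with a 4.3-fold lower number from compound 2 to compound 4 (0.63 log units; beyond the scatter), which means higher toxicity in this test on the second core as on the first. The size of the step also held up across the two cores: the same change on two cores in this assay, a 7.5-fold lower number (0.87 log units; beyond the scatter) from compound 3 to compound 1 and a 4.3-fold lower number (0.63 log units; beyond the scatter) from compound 2 to compound 4, 1.7-fold (0.24 log units) apart, within the scatter of two such steps. This shows that the change carried over between these two cores in this one test, but it does not show why the number falls or that the same step would appear on any other core.

No pair shown isolates the methoxy group, so its separate contribution to the values remains open. Also open, from the compounds shown here alone, is how the number would respond if a dimethylamino group, an acetamide or a carboxylic acid stood in the place taken here by amino, on either core.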